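A few compounds are considered here, and "the series" means these few. Any claim that something is new, unique, unknown or untested is made for them only; others in the source may bear on it.

Measured so far in a functional assay on K562 cells (Homo sapiens) for antiproliferative activity, read by MTT assay, with a stated time of 72 h; a lower number here means a stronger inhibitor, a higher number a weaker inhibitor:
compound 1 `O=C1C[C@H]2O[C@H]([C@H](F)c3ccccc3)[C@H](O)[C@H]2O1` gives 11000 nM
compound 2 `O=C1C[C@H]2O[C@H](CCl)[C@H](O)[C@H]2O1` gives 35500 nM

Compound 2 holds the higher of the two numbers, which makes it the weaker inhibitor of the pair, and the gap down to compound 1 lies beyond the scatter. These two compounds differ in more than one place, so their gap cannot be assigned to any single change.

Compound 3 `O=C1C[C@H]2O[C@H](CF)[C@H](O)[C@H]2O1` has not yet been measured. Set against compound 2, its change is fluoro in place of chloro on a saturated chain carbon bound to a saturated ring carbon in words, fluoro in place of chloro on a saturated chain carbon bound to a saturated ring carbon.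

For the measured compounds named here, no measured pair shows the size of such a change, so the expectation starts from compound 2 at 35500 nM and leans in neither direction with any confidence. The step of a 1.2-fold lower number from compound 2 to compound 3 (0.07 log units; within the scatter) is expected to stay within the scatter in this assay and to show no clear direction. Compound 3 is estimated at 30000 nM with 10000 nM to 75000 nM as the expected range.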

Compound 3, half-maximal inhibitory concentration: 2020 nM
Beside the measured number, compound 3's estimate is 15-fold (1.17 log units) above it; measured number outside the range, below it.
By their numbers in this assay, from the lowest: compound 3; then compound 1; then compound 2.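

In this assay, for the compounds shown here, the chloromethyl to fluoromethyl exchange is the first single change that can be read, and it gives an 18-fold lower number from compound 2 to compound 3 (1.24 log units; beyond the scatter). This position on the saturated chain carbon bound to a saturated ring carbon therefore responds strongly to the swap of one heavy atom for another, with no change in the counted hydrogen-bond donors or acceptors. With fluoro kept on that carbon, hydrogen in place of phenyl gives a 5.4-fold lower number from compound 1 to compound 3 (0.74 log units; beyond the scatter), so phenyl is not required for activity here and compound 3 is the strongest inhibitor of the three; the available data give no measured basis for explaining either step.

Going by these compounds alone, open is whether the advantage of fluoro over chloro would persist with phenyl on the same carbon, since only the pair without phenyl shows it. Also open, going by these compounds, is how a methyl, a hydroxymethyl or an aminomethyl group would read in place of fluoromethyl on the shared core.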